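Replacement of the aromatic group on the chain carbon of compound 1

A few compounds are considered here, and "the series" means these few. Any claim that something is new, unique, unknown or untested is made for them only; others in the source may bear on it.

Compound 1 `N=C(N)c1ccc(Cn2cnc3cc(C(=O)NCCC(=O)O)ccc32)cc1` is the weakest member of the three measured in a functional assay (plasma) for inhibition, with Homo sapiens as the target; on this read-out higher numbers stand for weaker inhibition and lower numbers for stronger inhibition: compound 1 gives 6800 nM, the highest of the three numbers. Compound 2 `CCCCOC(=O)N[C@@H](CNC(=O)c1ccc2nc(-c3ccc(C(=N)N)cc3)oc2c1)C(=O)O` gives 20 nM in this assay, and compound 3 `CCCCOC(=O)N[C@@H](CNC(=O)c1ccc2oc(-c3ccc(C(=N)N)cc3)nc2c1)C(=O)O` gives 20 nM; both stand well apart from compound 1, and their two values lie within the scatter of each other.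

Compound 4 `O=C(O)CCNC(=O)c1ccc2c(c1)ncn2CCCC1CCNCC1` is not yet measured. It differs from compound 1 in one place: a group of 8 heavy atoms (7 carbon, 1 nitrogen; one six-membered non-aromatic ring with 1 hetero atom) in place of a group of 9 heavy atoms (7 carbon, 2 nitrogen; one six-membered aromatic ring of carbon only), on a saturated chain carbon bound to an aromatic nitrogen. Among the measured compounds shown here, no measured pair in the set shows this kind of exchange, so the size of its effect is unknown. Since the group that leaves is shared by compounds 1, 2 and 3, and compound 1 already stands at 6800 nM, the expectation is a modest loss rather than a gain. The step from compound 1 to compound 4 is expected to be a 2.2-fold higher number from compound 1 to compound 4 (0.34 log units; beyond the scatter). Compound 4 is therefore estimated at 15000 nM, in a range from 3000 nM to 60000 nM, with a real chance that this assay reports only a limit.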

Compound 4, half-maximal inhibitory concentration: 16000 nM
Estimate against measurement, compound 4: 1.1-fold (0.03 log units) below; low and high end bracket the measured number.
By their numbers in this assay, from the lowest: compounds 2 and 3 (each within the scatter of the next); then compound 1; then compound 4.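

Exchanging the group that carries the aromatic ring for 2-(piperidin-4-yl)ethyl, on a saturated chain carbon bound to an aromatic nitrogen, gives a 2.4-fold higher number from compound 1 to compound 4 (0.37 log units; beyond the scatter) in this assay. Among the compounds shown here, this is the first measured exchange at this place: the aromatic ring and the double bond outside it can be given up at a modest cost, and the read-out remains a number, not a limit. Nothing measured bears on the reason for this step.

Still open, on these data alone, is whether a primary amine on an open chain, in place of the piperidine ring, would hold the same level, and whether a longer chain to the piperidine ring would move the number. As far as these compounds go, with a single pair, the size of this exchange on any other core also remains untested.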